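The source may report more compounds than this note shows. Statements on the series, on what has been measured and on what is new or still open speak of the compounds shown alone.

Compound 1 `COc1cc(/C=C/c2cc(-c3ccc(O)cc3)[nH]n2)cc(OC)c1`: 10600 nM
Compound 2 `COc1cc(/C=C/c2cc(-c3ccc(O)c(OC)c3)[nH]n2)ccc1O`: 4000 nM
Compound 3 `COc1cc(/C=C/c2cc(-c3ccc(O)c(OC)c3)[nH]n2)cc(OC)c1`: not yet measured

Within the data shown here, in a functional assay on SH-SY5Y cells (Homo sapiens) for cytotoxicity, read by MTT assay, with a stated time of 48 h (on this read-out higher numbers stand for weaker inhibition and lower numbers for stronger inhibition), compound 1 gives 10600 nM, the higher of the two numbers so far. Compound 2 gives 4000 nM, and this gap lies beyond the usual scatter. Compound 3 keeps the core of compound 1 and changes it in one place: methoxy in place of hydrogen on an aromatic carbon. This is methoxy in place of hydrogen on an aromatic carbon, ortho to a hydroxy group and meta to a large group. Among the measured compounds shown here, no measured pair shows this change alone. Compound 2, at 4000 nM, also carries a methoxy there but differs elsewhere too, so it is only a loose guide. A modest move towards a lower number is therefore expected, possibly not beyond the scatter. The expected step is a 1.5-fold lower number from compound 1 to compound 3 (0.18 log units; within the scatter). Compound 3 is estimated at 7000 nM, with an expected range of 2500 nM to 20000 nM.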

Compound 3, half-maximal inhibitory concentration: 11800 nM
Beside the measured number, compound 3's estimate is 1.7-fold (0.23 log units) below it, within the range that was stated.
By their numbers in this assay, from the lowest: compound 2; then compounds 1 and 3 (each within the scatter of the next).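

In this assay, methoxy in place of hydrogen on an aromatic carbon, ortho to a hydroxy group and meta to a large group, gives a 1.1-fold higher number from compound 1 to compound 3 (0.05 log units; within the scatter). This is the first pair shown that differs in this one place alone, and it shows that, on the core of compound 1, adding this methoxy produces no change that can be told from the usual scatter. No measurement is available that would explain this result.

From the compounds shown here alone, one group says little about the position as a whole, so it remains open how an amine, a carboxylic acid or a longer chain such as ethoxy would behave there. Going by these compounds, it also remains open whether the same methoxy would give a similar result if other parts of the molecule carried different groups.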